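Replacing a Hydroxyphenyl Group with a Fluorophenyl Group

The source may report more compounds than this note shows. Statements on the series, on what has been measured and on what is new or still open speak of the compounds shown alone.

Of the compounds shown here, two sharing one core have been measured so far. Compound 1 `COc1c(C)cnc(C[S+]([O-])c2nnc(-c3cccc(F)c3)o2)c1C` carries a 3-fluorophenyl group; in a functional assay on HUVEC cells (Homo sapiens) for inhibition, read by ELISA (on this read-out higher numbers stand for weaker inhibition and lower numbers for stronger inhibition), compound 1 gives 15000 nM. Compound 2 `COc1c(C)cnc(C[S+]([O-])c2nnc(-c3ccccc3O)o2)c1C` carries a 2-hydroxyphenyl group at the same place, and in this assay compound 2 gives 10000 nM. The change between them amounts to a 1.5-fold lower number from compound 1 to compound 2 (0.18 log units; within the scatter). Compound 2 thus has the lowest of the two numbers shown, but since the gap to compound 1 lies within the scatter, neither compound can be called the stronger one.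

Compound 3 `COc1c(C)cnc(C[S+]([O-])c2nnc(-c3ccc(F)cc3)o2)c1C` has not yet been measured. Compared with compound 2 it shows this difference: 4-fluorophenyl in place of 2-hydroxyphenyl on an aromatic carbon. Among the measured compounds shown here, the only measured step that bears on this exchange is a 1.5-fold lower number from compound 1 to compound 2 (0.18 log units; within the scatter), which swapped a fluorophenyl for a hydroxyphenyl group without a shift beyond the scatter. For the measured compounds named here, no measured step compares a 4-fluorophenyl with a 3-fluorophenyl group, so that part of the change is untested. Going back from hydroxyphenyl to fluorophenyl is therefore expected to give no step beyond the scatter, roughly a 1.3-fold higher number from compound 2 to compound 3 (0.11 log units; within the scatter). Compound 3 is estimated at 13000 nM, with a range from 5000 nM to 35000 nM.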

Compound 3, half-maximal inhibitory concentration: 14000 nM
Compound 3: the middle estimate sits 1.1-fold (0.03 log units) below what was measured; the measured number falls inside the stated range.
By their numbers in this assay, from the lowest: compounds 2, 3 and 1 (each within the scatter of the next).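

The fluorine on the phenyl ring now has a measured comparison: in this assay, moving from 3-fluorophenyl to 4-fluorophenyl gives a 1.1-fold lower number from compound 1 to compound 3 (0.03 log units; within the scatter) and so leaves the read-out unchanged within the scatter. The exchange of 2-hydroxyphenyl for 4-fluorophenyl, which removes the hydrogen-bond donor and acceptor counted on the 2-hydroxyphenyl group, gives a 1.4-fold higher number from compound 2 to compound 3 (0.15 log units; within the scatter) and also produces no shift beyond the scatter, so at this place on the five-membered aromatic ring the three phenyl groups cannot be told apart. No supporting data are available to explain this similarity.

All three compounds shown keep a six-membered aromatic ring of carbon at this place, so it remains open whether a group of another kind, such as an amine, a carboxylic acid or a longer alkyl chain, would move the number beyond the scatter. Going by these compounds, it is also open whether a change elsewhere on the shared core would matter more than these exchanges on the phenyl ring.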